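The source may report more compounds than this note shows. Statements on the series, on what has been measured and on what is new or still open speak of the compounds shown alone.

Compound 1 `Cc1ccccc1C(=O)Nc1nnc(-c2ccc3c(c2)OCCO3)s1` — in a functional assay on HepG2 cells (Homo sapiens) for antiproliferative activity, read by MTT assay, with a stated time of 48 h (on this read-out higher numbers stand for an effect only at larger amounts of compound and lower numbers for an effect already at smaller amounts), compound 1 gives > 100 ug/mL, which is a limit of the assay and not a number.
Compound 2 `O=C(Nc1nnc(-c2ccc3c(c2)OCCO3)s1)c1ccccn1` — in this assay compound 2 gives > 100 ug/mL, again a limit of the assay and not a number.

Going by the values given here, compound 2 therefore stands only at a limit, and the same holds for the one other measured compound: both values sit at the limit of > 100 ug/mL in this assay, at which 2 of the 2 values shown sit. Among the compounds with values here, the single measured step, a step that the two limits leave unreadable from compound 1 to compound 2, is left unreadable by the two limits, so its size is unknown. Compound 3 `Cc1ccc(C(=O)Nc2nnc(-c3ccc4c(c3)OCCO4)s2)cn1` differs from compound 2 by 6-methylpyridin-3-yl in place of pyridin-2-yl on a carbonyl carbon. Within the data shown here, no readable measured step bears on this change, and nothing among the measured values points to a step beyond the scatter in either direction. The step expected in this assay is therefore a number no higher from compound 2 to compound 3 (the limit leaves the size open). For compound 3 the estimate in this assay is 100 ug/mL, with a range from 50 ug/mL to 200 ug/mL, and most likely the assay again reports only a limit.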

Compound 3, half-maximal effective concentration: > 100 ug/mL
Compound 3: no number, only a limit (the forecaster's own chance of this, stated with the estimate: 80%); the middle value sits exactly at the limit.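

No step can be read among compound 1, compound 2 and compound 3, because each value is a limit and not a number: the limit of > 100 ug/mL in this assay, at which 3 of the 3 values shown sit. The compounds shown leave open how far these three actually differ in this assay and whether any group on the carbonyl carbon matters there.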